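Benzyl triazole amides: a third methoxy on the benzyl ring

A few compounds are considered here, and "the series" means these few. Any claim that something is new, unique, unknown or untested is made for them only; others in the source may bear on it.

In a functional assay on HeLa cells (Homo sapiens) for antiproliferative activity, read by sulforhodamine B assay, with a stated time of 48 h (a lower number here means a stronger inhibitor of growth, a higher number a weaker inhibitor of growth), compound 2 `COc1ccc(-c2nn(-c3ccccc3)cc2C(=O)NCc2cn(Cc3cc(OC)cc(OC)c3)nn2)cc1` gives 12400 nM, the highest of the two numbers measured. Its nearest neighbour is compound 1 `COc1ccc(-c2nn(-c3ccccc3)cc2C(=O)NCc2cn(Cc3ccc(C(F)(F)F)cc3)nn2)cc1`, which in this assay gives 6200 nM; the step of a 2.0-fold higher number from compound 1 to compound 2 (0.30 log units; within the scatter) lies within the scatter, so the two compounds cannot be ordered. Compound 3 `COc1ccc(-c2nn(-c3ccccc3)cc2C(=O)NCc2cn(Cc3cc(OC)c(OC)c(OC)c3)nn2)cc1` differs from compound 2 by methoxy in place of hydrogen on an aromatic carbon. Within the data shown here, the only measured step, a 2.0-fold higher number from compound 1 to compound 2 (0.30 log units; within the scatter), exchanges one benzyl aryl for another and never adds or removes a single methoxy group; it bears on the present change only loosely and was itself small. Among the measured compounds shown here, there is no direct precedent for this change among the measured compounds. No step beyond the scatter is therefore expected in this assay, in either direction. Compound 3 is estimated at 12000 nM, with a range from 4000 nM to 36000 nM. The implied step a 1.0-fold lower number from compound 2 to compound 3 (0.01 log units; within the scatter) is expected to stay within the scatter.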

Compound 3, concentration for 50% growth inhibition: 1700 nM
The estimate for compound 3 lay 7.1-fold (0.85 log units) above the measured number; the measured number lies below the stated range.
By their numbers in this assay, from the lowest: compound 3; then compounds 1 and 2 (each within the scatter of the next).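

Working from this assay, the aromatic carbon ortho to two methoxy groups and para to a large group is sensitive to substitution: methoxy in place of hydrogen there gives a 7.3-fold lower number from compound 2 to compound 3 (0.86 log units; beyond the scatter). The earlier exchange of one benzyl aryl for another stayed within the scatter, so it gave no sign that the benzyl ring could move this read-out. The 3,4,5-trimethoxyphenyl compound also separates from the 4-(trifluoromethyl)phenyl compound, with a 3.6-fold lower number from compound 1 to compound 3 (0.56 log units; beyond the scatter), although compounds 1 and 2 cannot be ordered. No measurement available here explains the step.

As far as these compounds go, whether ethoxy, a hydroxy group or an amine on this same aromatic carbon would give a step of similar size remains open. Also open, from the compounds shown here alone, is whether methoxy at this carbon has the same effect without the two methoxy groups ortho to it.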